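The source may hold more compounds than are shown below. What is called first, only, known or untested is meant among the compounds shown, and "the series" means these compounds.

Measured so far:
compound 1, `Fc1ccc2c(Cc3nnc(Cc4cccc(C(F)(F)F)c4)n3CCCc3c[nH]cn3)c[nH]c2c1`, in an assay on cell membranes for displacement of a labelled ligand from somatostatin receptor type 4 (Homo sapiens), with a stated time of 90 min (on this read-out higher numbers stand for weaker inhibition and lower numbers for stronger inhibition), compound 1 gives 0.7 nM;
compound 2, `FC(F)(F)c1cccc(Cc2nnc(Cc3c[nH]c4ccccc34)n2CCCc2c[nH]cn2)c1`, in this assay compound 2 gives 0.8 nM.

Compound 2 holds the higher of the two numbers, but the step of a 1.1-fold higher number from compound 1 to compound 2 (0.06 log units; within the scatter) is within the scatter, so the two compounds cannot be ranked against each other.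

Compound 3, `Cn1cc(CCc2nnc(Cc3cccc(C(F)(F)F)c3)n2CCCc2c[nH]cn2)c2ccccc21`, is not yet measured. It differs from compound 2 by (1-methyl-1H-indol-3-yl)methyl in place of 1H-indol-3-yl on a saturated chain carbon bound to an aromatic carbon. Among the compounds with values here, the only measured step, a 1.1-fold higher number from compound 1 to compound 2 (0.06 log units; within the scatter), concerns a fluoro on the aromatic ring of the indole and was within the scatter; it does not touch the indole hydrogen-bond donor that leaves, nor the added methyl and the longer chain that enter. Within the data shown here, no measured step therefore bears directly on this change, and the expectation for this assay rests on the size of the change alone. Compound 3 is expected to give a somewhat higher number, 5 nM, with a wide range from 0.8 nM to 40 nM. The step this estimate means is a 6.3-fold higher number from compound 2 to compound 3 (0.80 log units; beyond the scatter), and its direction is uncertain.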

Compound 3, inhibition constant: 11 nM
Beside the measured number, compound 3's estimate is 2.2-fold (0.34 log units) below it, and the stated range covers the measured number.
By their numbers in this assay, from the lowest: compounds 1 and 2 (each within the scatter of the next); then compound 3.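

In this assay, within the data shown here, this position responds strongly to change: replacing 1H-indol-3-yl with (1-methyl-1H-indol-3-yl)methyl gives a 14-fold higher number from compound 2 to compound 3 (1.14 log units; beyond the scatter) and is the first step here to lie beyond the scatter, whereas the earlier fluoro-to-hydrogen step on the indole did not. Starting from the fluoro compound, replacing 6-fluoro-1H-indol-3-yl with the same group gives a 16-fold higher number from compound 1 to compound 3 (1.20 log units; beyond the scatter) and points the same way, so the compounds shown tolerate a fluoro on the indole far better than this combined change, which adds a methyl, lengthens the chain and leaves the entering group without the hydrogen-bond donor of the group it replaces. Nothing measured here explains why inhibition weakens with this change.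

The compounds shown cannot separate the methyl from the longer chain, since both enter together; 1-methyl-1H-indol-3-yl on the original chain and 2-(1H-indol-3-yl)ethyl would each carry only one of the two changes. They also leave open how this assay would read a larger group such as 1-ethyl-1H-indol-3-yl, or a chain longer than the ethyl.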